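The source may hold more compounds than are shown below. What is called first, only, known or untested is meant among the compounds shown, and "the series" means these compounds.

Measured in an assay on isolated protein for inhibition of mitogen-activated protein kinase kinase kinase 14 (Homo sapiens), read by ADP-Glo, with a stated time of 60 min, tested at 100 uM, in the presence of a further agent that is not named here; a lower number here means less inhibition, a higher number more inhibition at the concentration tested (going by the name of the read-out):
compound 1 `O=C(Nc1cc(C(F)(F)F)cc(C(F)(F)F)c1)c1nsnc1O` gives 4.34%
compound 2 `Cn1nc(O)c(C(=O)Nc2cc(C(F)(F)F)cc(C(F)(F)F)c2)n1` gives 9.1%
compound 3 `Nc1nonc1C(=O)Nc1cc(C(F)(F)F)cc(C(F)(F)F)c1` gives -9.2%

Compound 3 stands lowest of the three: the two steps into it are a number 13.5 percentage points lower from compound 1 to compound 3 (beyond the scatter) and a number 18.3 percentage points lower from compound 2 to compound 3 (beyond the scatter), both beyond the scatter, while compound 1 and compound 2 lie within the scatter of each other, a number 4.8 percentage points higher from compound 1 to compound 2 (within the scatter).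

Compound 4 `Cn1cc(C(=O)Nc2cc(C(F)(F)F)cc(C(F)(F)F)c2)c(O)n1` is not yet measured. Change from compound 3: 3-hydroxy-1-methyl-1H-pyrazol-4-yl in place of 4-amino-1,2,5-oxadiazol-3-yl on a carbonyl carbon

For the measured compounds named here, both steps into compound 3 swap the ring on the carbonyl carbon, and both ran downward; the closest precedent is the step from the hydroxy-bearing ring of compound 2, a number 18.3 percentage points lower from compound 2 to compound 3 (beyond the scatter). Reversing that direction is expected for compound 4, a modest step upward of a number 15.2 percentage points higher from compound 3 to compound 4 (beyond the scatter) back toward the values of compound 1 and compound 2, giving an estimated 6%, range -9% to 21%.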

Compound 4, a percentage reported as inhibition, at one concentration (the size of the read-out at that concentration, not a potency): 7.23%
Beside the measured number, compound 4's estimate is 1.2 percentage points below it; low and high end bracket the measured number.
By their numbers in this assay, from the lowest: compound 3; then compounds 1, 4 and 2 (each within the scatter of the next).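

On the carbonyl carbon, 3-hydroxy-1-methyl-1H-pyrazol-4-yl in place of 4-amino-1,2,5-oxadiazol-3-yl gives a number 16.4 percentage points higher from compound 3 to compound 4 (beyond the scatter), while a number 1.9 percentage points lower from compound 2 to compound 4 (within the scatter) and a number 2.9 percentage points higher from compound 1 to compound 4 (within the scatter) both stay within the scatter. All three hydroxy-bearing rings now group together and the one amino-bearing ring sits apart, a pattern with no exception among these four compounds but resting on them alone. Nothing available explains this separation.

From the compounds shown here alone, whether any group at this position gives more than weak inhibition remains open. A carboxylic acid in place of the hydroxy group would test whether the hydroxy group itself matters.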